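This account rests on a few compounds, and the source may have more. Where it says the series, first, only, none or still open, it means among the compounds named here.

This study compares three measured compounds and one still to be tested. Compound 1 `O=[N+]([O-])c1ccc([C@@H]2OC[C@H]3O[C@@H](c4ccccc4)[C@H](O)[C@@H](O)[C@@H]3O2)cc1` gives 50 ug/mL in a functional assay on HEL cells (Homo sapiens) for cytotoxicity; a lower number here means that less compound is tolerated, a higher number that more compound is tolerated. Compound 2 `O[C@@H]1[C@@H](O)[C@H](c2ccccc2)O[C@@H]2CO[C@@H](c3ccc4ccccc4c3)O[C@@H]12` reaches only a limit in this assay, reported as >= 400 ug/mL. Compound 3 `CO[C@@H]1[C@@H](OC)[C@H](c2ccccc2)O[C@@H]2CO[C@@H](C3CCCCC3)O[C@@H]12` gives 20 ug/mL in this assay, the lowest of the two numbers measured; the nearest number belongs to compound 1, whose higher reading lies beyond the usual scatter of this kind of measurement. The remaining reading, for compound 2, is the limit of >= 400 ug/mL in this assay, at which 1 of the 3 values shown sits, and not a number.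

Compound 4 `CO[C@@H]1[C@@H](OC)[C@H](c2ccccc2)O[C@@H]2CO[C@@H](c3ccc(Cl)cc3)O[C@@H]12` differs from compound 3 in one place: 4-chlorophenyl in place of cyclohexyl on a saturated ring carbon. Within the data shown here, no measured pair differs in only that place, so the size of the step can only be estimated. Compound 2, which also carries an aromatic ring in the position described, sits at the limit of >= 400 ug/mL in this assay, at which 1 of the 3 values shown sits, but it carries free hydroxyl groups where compound 3 and compound 4 carry methoxy groups, so it is not a direct guide. The step of a 1.5-fold higher number from compound 3 to compound 4 (0.18 log units; within the scatter) is expected to be small, toward a somewhat higher tolerated concentration, and may fall within the scatter. Compound 4 is therefore estimated to give about 30 ug/mL in this assay, with a plausible range from 10 ug/mL to 100 ug/mL.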

Compound 4, minimum cytotoxic concentration: >= 100 ug/mL
Compound 4 gave a limit, no number; the forecaster's own chance of this, stated with the estimate: 10%; at least 3.3-fold (0.52 log units) between middle value and limit.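

Among these compounds, replacing cyclohexyl with 4-chlorophenyl on the saturated ring carbon between two ring oxygen atoms gives the first single change that can be read at this position, and in this assay it produces an at least 5.0-fold higher number from compound 3 to compound 4 (0.69 log units; beyond the scatter), so with the rest of the structure unchanged, the HEL cells tolerate more of the compound carrying the aromatic ring. Among the compounds shown here, no earlier pair differed in this place alone, so the compounds before this result could not tie a shift in tolerance to this position. The step is also a minimum and not a full measure of the change, since the reading for compound 4 is a limit and not a number: the limit of >= 100 ug/mL in this assay, at which 1 of the 4 values shown sits.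

The compounds shown cannot separate the contribution of the aromatic ring from that of the chlorine, and a plain phenyl or a 4-fluorophenyl on this same carbon would be the natural way to tell them apart. They also leave open how this position responds to a group of a different kind, such as a straight hexyl chain or a ring carrying an amine.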